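Methyl on the Ring Nitrogen of an Inactive Scaffold

The compounds below may be only part of what the source reports. "The series", "measured", "known", "first", "only" and "open" are said of these compounds alone.

Compound 1 `O=C(CSc1nc2cc[nH]c2c(=O)n1-c1ccccc1)NC1CCCCC1` was examined in an assay on HEK293 cells for agonist activity at Toll-like receptor 4 (Homo sapiens), read by colorimetric assay, with a stated time of 24 h; on this read-out higher numbers stand for an effect only at larger amounts of compound and lower numbers for an effect already at smaller amounts. In this assay compound 1 gives > 10000 nM, which is a limit of the assay rather than a measured number. A close relative, compound 2 `Cc1[nH]c2c(=O)n(-c3ccccc3)c(SCC(=O)NC3CCCCC3)nc2c1C`, carries two methyl groups on the five-membered ring of the shared core. In this assay compound 2 gives > 10000 nM, again a limit and not a number. Both known values therefore sit at the limit of > 10000 nM in this assay, at which 2 of the 2 values shown sit, and neither compound shows any effect within the range that was tested.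

Compound 3 `Cn1ccc2nc(SCC(=O)NC3CCCCC3)n(-c3ccccc3)c(=O)c21` differs from compound 1 by methyl in place of hydrogen on an aromatic nitrogen, a methyl in place of hydrogen on an aromatic nitrogen. For the measured compounds named here, no pair of measured compounds that differ in a single place is available, so the size of such a step cannot be read from a measured comparison. Because both known compounds sit at the limit of > 10000 nM in this assay, at which 2 of the 2 values shown sit, compound 3 is expected to show no effect up to the limit either. Compound 3 is estimated at 10000 nM, with a range from 4000 nM to 30000 nM. The expected step of a number no higher from compound 1 to compound 3 (the limit leaves the size open) is essentially none beyond the scatter.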

Compound 3, half-maximal effective concentration: > 10000 nM
Compound 3 gave a limit, no number (the forecaster's own chance of this, stated with the estimate: 85%); the middle value lies on the limit itself.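

Compound 1 and compound 3 each end at a limit of the assay rather than a number, so no step can be read for methyl in place of hydrogen on an aromatic nitrogen: (the limit of > 10000 nM in this assay, at which 3 of the 3 values shown sit). The compounds shown leave open whether any change to the shared core can bring an effect in this assay within the tested range.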